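Side-chain phenyl on the unsubstituted core: compound 4

The source may report more compounds than this note shows. Statements on the series, on what has been measured and on what is new or still open speak of the compounds shown alone.

Measured in a functional assay on A549 cells (Homo sapiens) for cytotoxicity, read by MTT assay, with a stated time of 72 h; on this read-out higher numbers stand for weaker inhibition and lower numbers for stronger inhibition:
compound 1 `CCCOCNc1n[n+]([O-])c2cc(OC)ccc2[n+]1[O-]` gives 2810 nM
compound 2 `COc1ccc2c(c1)[n+]([O-])nc(NCOC(C)c1ccccc1)[n+]2[O-]` gives 3130 nM
compound 3 `COCNc1n[n+]([O-])c2ccccc2[n+]1[O-]` gives 7450 nM

Compound 3 gives the highest number of the three in this assay; compound 2 and compound 1 both lie below it by gaps beyond the scatter, while compound 1 and compound 2 are within the scatter of each other. Compound 4 `[O-][n+]1nc(NCOCc2ccccc2)[n+]([O-])c2ccccc21` differs from compound 3 by phenyl in place of hydrogen on a saturated chain carbon bound to an oxygen on a saturated carbon. Within the data shown here, the only measured step at this place, a 1.1-fold higher number from compound 1 to compound 2 (0.05 log units; within the scatter), is within the scatter, though there the chain already carried propyl and both compounds 1 and 2 bear a methoxy on the core that compound 3 lacks. A modest move toward the numbers of compounds 1 and 2 is therefore expected for compound 4, as a 1.7-fold lower number from compound 3 to compound 4 (0.22 log units; within the scatter). The estimate for compound 4 is 4500 nM, between 2000 nM and 10000 nM.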

Compound 4, half-maximal inhibitory concentration: 10800 nM
Compound 4: the middle estimate sits 2.4-fold (0.38 log units) below what was measured, outside the stated range (above it).
By their numbers in this assay, from the lowest: compounds 1 and 2 (each within the scatter of the next); then compounds 3 and 4 (each within the scatter of the next).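

In this assay, among these compounds, the first step on the unsubstituted core, phenyl in place of hydrogen on a saturated chain carbon bound to an oxygen on a saturated carbon, gives a 1.4-fold higher number from compound 3 to compound 4 (0.16 log units; within the scatter). The side-chain phenyl therefore does not separate compound 4 from compound 3, and this adds a second within-scatter step at this place to a 1.1-fold higher number from compound 1 to compound 2 (0.05 log units; within the scatter). No supporting data bear on the reason for this result.

As far as these compounds go, compounds 1 and 2 differ from compounds 3 and 4 in more than one place, so the source of their gap remains open. An amine or a carboxylic acid on this chain carbon also remains untested in the compounds shown.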